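The compounds below may be only part of what the source reports. "The series", "measured", "known", "first", "only" and "open" are said of these compounds alone.

- compound 1 `C[N+]1(CC2CCCCC2)CCc2c(sc(NC(=O)Nc3ccc(Cl)cc3)c2C(N)=O)C1` gives 100 nM
- compound 2 `C[N+]1(CC2CC2)CCc2c(sc(NC(=O)Nc3ccc(Cl)cc3)c2C(N)=O)C1` gives 360 nM

In a functional assay (strain AB) with Danio rerio as the target, read by microscopy, with a stated time of 1 h (a lower number here means that less compound is needed, a higher number that more compound is needed for the effect), compound 2 stands at 360 nM, the higher of the two numbers, so more of it is needed for the effect than of compound 1. Compound 3 `C[N+]1(CC2CCCC2)CCc2c(sc(NC(=O)Nc3ccc(Cl)cc3)c2C(N)=O)C1` has not yet been measured. It carries cyclopentyl in place of cyclopropyl on a saturated chain carbon bound to an amine nitrogen in a ring. Among the measured compounds shown here, one measured step bears on this, at the same place: a 3.6-fold higher number from compound 1 to compound 2 (0.56 log units; beyond the scatter), with cyclopropyl in place of cyclohexyl. Going back from cyclopropyl to a larger carbon ring should therefore recover much of that difference, though a single step is thin evidence. The expected change is a 2.4-fold lower number from compound 2 to compound 3 (0.38 log units; beyond the scatter), towards a lower number. For compound 3 the estimate is 150 nM, with an expected range from 70 nM to 320 nM.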

Compound 3, half-maximal effective concentration: 200 nM
For compound 3 the middle estimate is 1.3-fold (0.12 log units) below the measured one; low and high end bracket the measured number.
By their numbers in this assay, from the lowest: compounds 1, 3 and 2 (each within the scatter of the next, the first and the last beyond it).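

In this assay compound 3 adds a ring of intermediate size at this position: cyclopentyl in place of cyclopropyl gives a 1.8-fold lower number from compound 2 to compound 3 (0.26 log units; within the scatter), and cyclopentyl in place of cyclohexyl gives a 2.0-fold higher number from compound 1 to compound 3 (0.30 log units; within the scatter). Both steps lie within the scatter, so compound 3 cannot be told apart from either of the other two, and the one clear difference at this position remains a 3.6-fold higher number from compound 1 to compound 2 (0.56 log units; beyond the scatter), which appears only between the smallest and the largest ring shown. Nothing shown here explains these differences.

Three carbon rings cannot settle how far this trend reaches or whether a ring is needed at all. A phenyl ring, an oxygen-containing tetrahydropyranyl ring or an open hexyl chain at this place could each help to answer that.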